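One Carbon More in the Ester Chain of Compound 3

The source may hold more compounds than are shown below. What is called first, only, known or untested is meant among the compounds shown, and "the series" means these compounds.

Compound 1, `COc1cc(/C=C/C(=O)OCCCCCO[N+](=O)[O-])ccc1OCCCCCO[N+](=O)[O-]`, in a functional assay on NCI-H157 cells (Homo sapiens) for cytotoxicity, read by resazurin assay, with a stated time of 72 h (on this read-out higher numbers stand for weaker inhibition and lower numbers for stronger inhibition), gives > 50000 nM, which is a limit of the assay rather than a number.
Compound 2, `O=C(/C=C/c1ccc(OCCCCCCO[N+](=O)[O-])c(O)c1)OCCCCCCO[N+](=O)[O-]`, gives > 50000 nM, likewise a limit and not a number.
Compound 3, `COc1cc(/C=C/C(=O)OCCCCCO[N+](=O)[O-])ccc1O`, gives 13400 nM.

For the measured compounds named here, compound 3 therefore holds the only number in this set; the two other values sit at the limit of > 50000 nM in this assay, at which 2 of the 3 values shown sit. Going by the values given here, the single step that can be read is an at least 3.7-fold lower number from compound 1 to compound 3 (0.57 log units; beyond the scatter), where a hydrogen replaces a 5-(nitrooxy)pentyl group on an oxygen of the aromatic ring; it moves the number downward and out of the scatter.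

Compound 4, `COc1cc(/C=C/C(=O)OCCCCCCO[N+](=O)[O-])ccc1O`, differs from compound 3 by (nitrooxy)methyl in place of nitrooxy on a saturated chain carbon, five bonds along the chain from an oxygen next to a carbonyl group. Among the compounds with values here, no measured step bears on a change of this kind: the one step known alters a different place, the oxygen on the aromatic ring, and leaves the ester chain untouched. Compounds 1 and 2 differ from each other in more than one place and both stand at a limit, so they show nothing about chain length alone. With no evidence for a shift in either direction, the step from compound 3 to compound 4 is expected to stay within the scatter, as no change at the digits printed from compound 3 to compound 4 (within the scatter). Compound 4 is accordingly estimated at 13400 nM, with a range from 5000 nM to 40000 nM.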

Compound 4, half-maximal inhibitory concentration: 32100 nM
The estimate for compound 4 lay 2.4-fold (0.38 log units) below the measured number; the measured number falls inside the stated range.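

For the compounds shown here, until compound 4, the only step that could be read lay on the oxygen on the aromatic ring, and nothing spoke to the ester chain. With (nitrooxy)methyl in place of nitrooxy on a saturated chain carbon, five bonds along the chain from an oxygen next to a carbonyl group, this assay shows a 2.4-fold higher number from compound 3 to compound 4 (0.38 log units; beyond the scatter), so this position is not silent: a change of a single carbon here moves the number beyond the scatter, and in the direction opposite to the step on the aromatic oxygen. Nothing measured in the set accounts for this rise.

From the compounds shown here alone, whether the number keeps rising with a still longer chain, or falls with a shorter one such as 4-(nitrooxy)butyl on the ester, stays open, and compounds 1 and 2 cannot settle it: they stand at limits and differ in more than one place, so steps involving them on this chain cannot be read. Equally open, going by these compounds, is what the same chain would give with a hydroxyl or an amine at its end in place of nitrooxy.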